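The source may hold more compounds than are shown below. What is called first, only, known or untested is meant among the compounds shown, and "the series" means these compounds.

Measured compounds:
compound 1 `O=C(N/N=C/c1cccc(F)c1)c1cccnc1Nc1cccc(C(F)(F)F)c1` gives 58.3% in a functional assay on the whole organism (strain Wistar) for inhibition, with Rattus norvegicus as the target, read by paw edema, with a stated time of 30 min, at a dose of 10 mg/kg by the intraperitoneal route; a lower number here means less inhibition, a higher number more inhibition at the dose given (going by the name of the read-out)
compound 2 `O=C(N/N=C/c1ccc(F)cc1)c1cccnc1Nc1cccc(C(F)(F)F)c1` gives 33.9% in this assay
compound 3 `COc1cccc(/C=N/NC(=O)c2cccnc2Nc2cccc(C(F)(F)F)c2)c1` gives 52.8% in this assay

Compound 3 stands second of the three on these numbers. Its nearest neighbour is compound 1, and the gap between them is within the scatter, so no order can be read between the two; compound 2 lies furthest from it, and the step of a number 18.9 percentage points higher from compound 2 to compound 3 (beyond the scatter) is beyond the scatter.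

Compound 4 `CN(C)c1ccc(/C=N/NC(=O)c2cccnc2Nc2cccc(C(F)(F)F)c2)cc1` has not yet been measured in this assay. It differs from compound 3 in one place: 4-(dimethylamino)phenyl in place of 3-methoxyphenyl on a carbon with a double bond to nitrogen. Going by the values given here, no measured step swaps a 3-methoxyphenyl for a 4-(dimethylamino)phenyl, so the bearing of the known steps is indirect. The step of a number 24.4 percentage points lower from compound 1 to compound 2 (beyond the scatter) moved a fluoro from the 3-fluorophenyl to the 4-fluorophenyl and brought the number down by a modest amount. The step of a number 5.5 percentage points lower from compound 1 to compound 3 (within the scatter) stayed within the scatter. Among the compounds with values here, on that basis a modest downward step is expected for compound 4, though with little confidence given that no measured pair shows a dimethylamino group at all. Compound 4 is therefore estimated at 40%, in the range 20% to 60%, which means an expected step of a number 12.8 percentage points lower from compound 3 to compound 4 (beyond the scatter).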

Compound 4, a percentage reported as inhibition, in the whole organism at one dose (the size of the read-out at that dose, not a potency): 61.3%
Beside the measured number, compound 4's estimate is 21.3 percentage points below it; measured number outside the range, above it.
By their numbers in this assay, from the lowest: compound 2; then compounds 3, 1 and 4 (each within the scatter of the next).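

In this assay, the step of a number 8.5 percentage points higher from compound 3 to compound 4 (within the scatter) and the step of a number 3 percentage points higher from compound 1 to compound 4 (within the scatter) both stay within the scatter, so compound 4 cannot be placed in any order against either of them, and a 4-(dimethylamino)phenyl on the carbon with a double bond to nitrogen reads alongside the 3-methoxyphenyl and the 3-fluorophenyl. The step of a number 27.4 percentage points higher from compound 2 to compound 4 (beyond the scatter) is the new information: until now the only 4-substituted phenyl was the 4-fluorophenyl of compound 2, so its low number could have been read as belonging to that position as such, whereas compound 4 shows that a group at the same place can go with a number at the level of the other compounds, and the low reading therefore stays tied to compound 2 alone. Nothing measured here accounts for the difference between fluoro and dimethylamino at this place.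

The compounds shown leave open whether this holds only for dimethylamino, or also for a methoxy, a primary amine or a carboxylic acid in its place on the same ring. They also leave open whether a dimethylamino group on the ring of the 3-substituted compounds would read the same, and a single dose gives no potency for any of them.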